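A few compounds are considered here, and "the series" means these few. Any claim that something is new, unique, unknown or untested is made for them only; others in the source may bear on it.

Working notes on the series.

Compound 1 `COC(=O)[C@@]1(C)CCC=C2[C@@H]1CC[C@@H](C)[C@]2(C)Cc1c[nH]c2ccc(Br)cc12` and compound 2 `COC(=O)[C@@]1(C)CCC=C2[C@@H]1CC[C@@H](C)[C@]2(C)Cc1c[nH]c2ccc(OC)cc12` share one core; compound 3 `COC(=O)[C@@]1(C)CC[C@@H]2C3=C1CC[C@@H](C)[C@]3(C)Cc1c2[nH]c2ccc(Br)cc12` and compound 4 `COC(=O)[C@@]1(C)CC[C@@H]2C3=C1CC[C@@H](C)[C@]3(C)Cc1c2[nH]c2ccc(OC)cc12` share another, and the difference between the two cores is not broken down here. In a functional assay on T47D cells (Homo sapiens) for inhibition, read by sulforhodamine B assay, with a stated time of 48 h (a higher number here means a weaker inhibitor of growth, a lower number a stronger inhibitor of growth), compound 1 gives 16000 nM. In this assay compound 2 gives 3700 nM. The change between them is methoxy in place of bromo on an aromatic carbon, and it made a step of a 4.3-fold lower number from compound 1 to compound 2 (0.64 log units; beyond the scatter). In this assay compound 3 gives 21000 nM; set against compound 1 the two numbers lie within the scatter, while the gap to compound 2 is beyond it.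

Compound 4 is not yet measured. It differs from compound 3 by methoxy in place of bromo on an aromatic carbon. This is the same kind of change as that from compound 1 to compound 2, not the same: in compound 1 the aromatic carbon sits in a six-membered aromatic ring of carbon only that is part of a fused or bridged system of two rings, whereas in compound 3 that ring is part of a fused or bridged system of five rings; in both it is meta to a fused ring and para to a fused ring.

In this assay the expected step is a 4.2-fold lower number from compound 3 to compound 4 (0.62 log units; beyond the scatter), because the earlier step of a 4.3-fold lower number from compound 1 to compound 2 (0.64 log units; beyond the scatter) came from the same pair of groups swapped at the same kind of place. For the measured compounds named here, only one earlier instance exists, so the range is kept wide. Compound 4 is estimated at 5000 nM, expected between 2000 nM and 13000 nM.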

Compound 4, concentration for 50% growth inhibition: 6500 nM
Estimate against measurement, compound 4: 1.3-fold (0.11 log units) below; measured number inside the range.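

In this assay, methoxy in place of bromo on an aromatic carbon gives a 3.2-fold lower number from compound 3 to compound 4 (0.51 log units; beyond the scatter), which runs in the same direction as the step on the other core, and the two steps do not differ in size: the same change on two cores in this assay, a 4.3-fold lower number (0.64 log units; beyond the scatter) from compound 1 to compound 2 and a 3.2-fold lower number (0.51 log units; beyond the scatter) from compound 3 to compound 4, 1.3-fold (0.13 log units) apart, within the scatter of two such steps. For this one pair of groups, at this one place, the change therefore carries from the core of compound 1 to the core of compound 3 with its size intact, so a step read on one of these two cores served as a fair guide to the other. This does not show that other swaps would carry over in the same way or that a third core would behave alike, as it rests on two steps in a single cell assay, and it gives no reason why methoxy gives the lower number.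

The compounds shown hold only bromo and methoxy on this aromatic carbon, so it remains open whether an amine, a carboxylic acid or a longer chain such as butoxy there would move the number in the same way on both cores. The methyl ester is also common to all four compounds, which leaves open what a carboxylic acid or an amide in its place would do in this assay.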